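Varying the N-aryl group on a shared quinolone-amide core

The source may report more compounds than this note shows. Statements on the series, on what has been measured and on what is new or still open speak of the compounds shown alone.

Compound 1 `O=C(Nc1ccc(Oc2ccnc3[nH]ccc23)cc1)c1cn(-c2ccc(Br)cc2)c2ccccc2c1=O`: 610 nM
Compound 2 `O=C(Nc1ccc(Oc2ccnc3[nH]ccc23)cc1)c1cn(-c2ccc(C(F)(F)F)cc2Cl)c2ccccc2c1=O`: 3570 nM

Among the compounds with values here, in a functional assay on MCF7 cells (Homo sapiens) for inhibition, read by MTT assay, with a stated time of 72 h (a higher number here means a weaker inhibitor, a lower number a stronger inhibitor), compound 2 gives the higher of the two numbers so far; compound 1 sits at the lower one, and the step of a 5.9-fold higher number from compound 1 to compound 2 (0.77 log units; beyond the scatter) lies beyond the scatter. Compound 3 `O=C(Nc1ccc(Oc2ccnc3[nH]ccc23)cc1)c1cn(-c2ccc(F)c(Cl)c2)c2ccccc2c1=O` differs from compound 2 by 3-chloro-4-fluorophenyl in place of 2-chloro-4-(trifluoromethyl)phenyl on an aromatic nitrogen. Within the data shown here, only the step from compound 1 to compound 2 bears on this change, and it moved the number up when the larger group entered. With a smaller group entering here, compound 3 is expected to return part of the way, a step of a 3.0-fold lower number from compound 2 to compound 3 (0.47 log units; beyond the scatter). Compound 3 is therefore estimated at 1200 nM, with a range from 400 nM to 3600 nM.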

Compound 3, half-maximal inhibitory concentration: 1510 nM
Compound 3: middle estimate off by 1.3-fold (0.10 log units), on the low side; measured number inside the range.
By their numbers in this assay, from the lowest: compound 1; then compound 3; then compound 2.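

In this assay, the N-aryl position responds to more than one kind of change: a 2.4-fold lower number from compound 2 to compound 3 (0.37 log units; beyond the scatter) shows that the number falls when 3-chloro-4-fluorophenyl enters, while a 2.5-fold higher number from compound 1 to compound 3 (0.39 log units; beyond the scatter) shows that this group does not match 4-bromophenyl. That step replaces trifluoromethyl with fluorine and also shifts the chlorine, so the two changes cannot be separated. No evidence is available to explain these differences.

As far as these compounds go, whether an unsubstituted phenyl group would rank above or below these three remains open. So does the effect of an amine or a carboxylic acid on that ring.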